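This account rests on a few compounds, and the source may have more. Where it says the series, first, only, none or still open, it means among the compounds named here.

Measured in an ADME assay on a cell-free system (plasma, Rattus norvegicus); a higher number here means a larger unbound share of the compound, a lower number a smaller unbound share:
- Compound 1 `CC(=O)Nc1cc(-c2ccc(N(C)C(=O)c3c(F)cccc3Cl)c(N3CC4CC4C3)c2)n(C2CCC2)n1`: 0.0004
- Compound 2 `CC(=O)Nc1cc(-c2cnc(N(C)C(=O)c3c(F)cccc3Cl)c(N3CCCCC3)c2)n(C(C)C)n1`: 0.013
- Compound 3 `CN(C(=O)c1c(F)cccc1Cl)c1ccc(-c2cc(C(N)=O)ccc2Cl)cc1OCC(F)(F)F`: 0.002

Compound 3 holds the middle place of the three numbers, above compound 1 and below compound 2, with both gaps beyond the scatter. Compound 4 `CC(C)n1nc(C(N)=O)cc1-c1ccc(N(C)C(=O)c2c(F)cccc2Cl)c(OCC(F)(F)F)c1` carries 3-carbamoyl-1-isopropyl-1H-pyrazol-5-yl in place of 5-carbamoyl-2-chlorophenyl on an aromatic carbon. Among the compounds with values here, no measured pair differs in one place only, so direct evidence is missing. Compound 2, which also has an isopropyl group on a pyrazole, gives 0.013, but its core differs. Compound 1 has a pyrazole too and gives 0.0004, which goes against any simple trend. A modest rise is expected, estimated as a 2.5-fold higher number from compound 3 to compound 4 (0.40 log units; beyond the scatter). Compound 4 is estimated at 0.005, with an expected range of 0.0015 to 0.016.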

Compound 4, unbound fraction in the plasma assay: 0.031
For compound 4 the middle estimate is 6.2-fold (0.79 log units) below the measured one, outside the stated range (above it).
By their numbers in the plasma assay, from the lowest: compound 1; then compound 3; then compound 2; then compound 4.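

Within the data shown here, in the plasma assay, putting 3-carbamoyl-1-isopropyl-1H-pyrazol-5-yl in place of 5-carbamoyl-2-chlorophenyl gives a 16-fold higher number from compound 3 to compound 4 (1.19 log units; beyond the scatter), the first change here that can be read in one place only. The unbound share thus depends strongly on the group at this aromatic carbon, para to a large group. In a physicochemical assay for solubility, measured as kinetic solubility (a lower number here means a less soluble compound, a higher number a more soluble compound), compound 3 gives 0.3 ug/mL and compound 4 gives 32 ug/mL. The same change also goes with a large rise in another property: the measured solubility of compound 3, 0.3 ug/mL, and of compound 4, 32 ug/mL, a 110-fold higher number (2.03 log units; beyond the scatter)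

The ring, the chlorine and the isopropyl group all change together, so the compounds shown cannot say which of them carries the step. From the compounds shown here alone, it also remains open how a pyrazole with methyl instead of isopropyl, or with a carboxylic acid instead of the carbamoyl group, would behave.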